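Carboxyphenyl position on the benzothiophene-linked acid series

The compounds below may be only part of what the source reports. "The series", "measured", "known", "first", "only" and "open" are said of these compounds alone.

Two acids of one shared core have been measured. Compound 1 `CC(C)c1onc(-c2c(Cl)cccc2Cl)c1COc1ccc2sc(-c3cccc(C(=O)O)c3)cc2c1` gives 32 nM in an assay on CV-1 cells with Bile acid receptor (Homo sapiens) as the target, read by a luciferase reporter; a higher number here means that more compound is needed for the effect, a lower number that less compound is needed. Compound 2 `CC(C)c1onc(-c2c(Cl)cccc2Cl)c1COc1ccc2cc(-c3cccc(C(=O)O)c3)sc2c1`, which carries the same pieces joined in a different arrangement, gives 63 nM in this assay. Of the two numbers, that of compound 2 is the highest; its nearest neighbour is compound 1, and the gap between them lies within the usual scatter, so the two cannot be told apart on these data.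

Compound 3 `CC(C)c1onc(-c2c(Cl)cccc2Cl)c1COc1ccc2cc(-c3ccc(C(=O)O)cc3)sc2c1` is not yet measured. Relative to compound 2 the change is 4-carboxyphenyl in place of 3-carboxyphenyl on an aromatic carbon of the five-membered ring next to the ring sulfur. Among the compounds with values here, no step between measured compounds bears on this change, so its size and direction are open; a move of the acid around the ring is expected to give at most a modest step, in either direction, and plausibly none beyond the scatter. The step that this estimate means, a 1.3-fold higher number from compound 2 to compound 3 (0.10 log units; within the scatter), is expected to stay small. Compound 3 is therefore expected near 80 nM, within a range from 25 nM to 300 nM.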

Compound 3, half-maximal effective concentration: 220 nM
The estimate for compound 3 lay 2.8-fold (0.44 log units) below the measured number, and the stated range covers the measured number.
By their numbers in this assay, from the lowest: compounds 1 and 2 (each within the scatter of the next); then compound 3.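

On the shared core of compound 2, the position of the acid on the phenyl group at the aromatic carbon next to the ring sulfur matters in this assay: 4-carboxyphenyl in place of 3-carboxyphenyl gives a 3.5-fold higher number from compound 2 to compound 3 (0.54 log units; beyond the scatter). Within the data shown here, this is the first readable step between compounds that differ in one place, and it lies beyond the scatter; the group that leaves and the group that enters have the same heavy-atom count and the same donor and acceptor counts, so these counts do not separate them. The data shown offer no measured basis for explaining the step.

Whether the same change gives a step of similar size and direction on the core of compound 1 remains open, since that core is shown only with 3-carboxyphenyl. On these data alone, it is also open how this position responds when the carboxylic acid is replaced by a tetrazole or a primary amide, or when a methyl ester stands in its place, so the present step describes only a move of the acid and not what the acid itself contributes.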